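A morpholine in place of an aminocyclohexyl group

The compounds below may be only part of what the source reports. "The series", "measured", "known", "first", "only" and "open" are said of these compounds alone.

Compound 1 (`CNc1ncc2cc(-c3ccc(-c4cncc(C)n4)cc3Cl)c(=O)n(C[C@H]3CC[C@H](N)CC3)c2n1`): 0.4 10^-6 cm/s
Compound 2 (`CCNc1ncc2cc(-c3ccc(-c4cncc(C)n4)cc3Cl)c(=O)n(CCCO)c2n1`): 21 10^-6 cm/s

In an ADME assay on MDCK cells (Canis lupus familiaris) for permeability, in the apical to basolateral direction, with a stated time of 60 min, tested at 10 uM (on this read-out higher numbers stand for higher permeability and lower numbers for lower permeability), compound 1 has the lower of the two numbers, and its gap to compound 2 lies well beyond the usual scatter. Compound 3 (`CNc1ncc2cc(-c3ccc(-c4cncc(C)n4)cc3Cl)c(=O)n(C[C@H]3CNCCO3)c2n1`) keeps the core of compound 1 and alters one group: morpholin-2-yl in place of 4-aminocyclohexyl on a saturated chain carbon bound to an aromatic nitrogen. In words, morpholin-2-yl takes the place of 4-aminocyclohexyl on a saturated chain carbon bound to an aromatic nitrogen. Among the compounds with values here, no measured pair shows this exact change, so any forecast remains loose. Compound 2 reaches 21 10^-6 cm/s, which shows that this series has room above compound 1. A moderate rise, beyond the scatter, is therefore expected, a 5.0-fold higher number from compound 1 to compound 3 (0.70 log units; beyond the scatter). For compound 3 the estimated value is 2 10^-6 cm/s, with an expected range of 0.6 10^-6 cm/s to 7 10^-6 cm/s.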

Compound 3, apparent permeability: 3.5 10^-6 cm/s
The estimate for compound 3 lay 1.8-fold (0.24 log units) below the measured number; the measured number falls inside the stated range.
By their numbers in this assay, from the lowest: compound 1; then compound 3; then compound 2.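

In this assay, this saturated chain carbon bound to an aromatic nitrogen proves sensitive to the ring it carries: morpholin-2-yl in place of 4-aminocyclohexyl gives a modest step beyond the usual scatter (an 8.8-fold higher number from compound 1 to compound 3 (0.94 log units; beyond the scatter)). The core of compound 1 stays untouched, and both groups hold one six-membered non-aromatic ring and 1 hydrogen-bond donor, so a change limited to this ring is enough to shift the number. No measurement at hand explains the rise.

This single step cannot separate the contribution of the ring oxygen from that of the ring nitrogen's new setting. It also leaves open whether a piperidin-3-yl group, or an open chain such as 2-aminoethyl, would give a similar number at this place.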